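The source may hold more compounds than are shown below. What is called first, only, known or untested is meant among the compounds shown, and "the series" means these compounds.

Measured compounds:
compound 1, `CCCCNc1nc(SC)nc2ncccc12`: 270 nM
compound 2, `COCCNc1nc(SC)nc2ncccc12`: 2530 nM

In a functional assay (Nicotiana tabacum) (a lower number here means a stronger inhibitor, a higher number a weaker inhibitor), compound 1 gives 270 nM, the lowest of the two numbers. For the measured compounds named here, compound 2 gives 2530 nM, and a 9.4-fold higher number from compound 1 to compound 2 (0.97 log units; beyond the scatter) is the only measured step. Compound 3, `CSc1nc(Nc2ccccc2)c2cccnc2n1`, has not yet been measured. It differs from compound 1 by phenyl in place of butyl on a nitrogen on an aromatic ring. Going by the values given here, the single measured step concerns a different change on the chain and so does not bear on replacing the whole butyl group with phenyl; no measured pair shows what an aromatic ring on that nitrogen does. The data give no basis for a direction, and the expectation rests on compound 1 alone with wide uncertainty either way. The step from compound 1 to compound 3 is therefore expected to be modest, a 1.9-fold higher number from compound 1 to compound 3 (0.27 log units; within the scatter). Compound 3 is estimated at 500 nM, within a range of 80 nM to 3500 nM.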

Compound 3, half-maximal inhibitory concentration: 15900 nM
Estimate against measurement, compound 3: 32-fold (1.50 log units) below; the whole stated range lies below it.
By their numbers in this assay, from the lowest: compound 1; then compound 2; then compound 3.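

In this assay, the group on a nitrogen on an aromatic ring can shift the number far more than the earlier change within the chain suggested: phenyl in place of butyl gives a 59-fold higher number from compound 1 to compound 3 (1.77 log units; beyond the scatter), a large step where the earlier one was modest. Phenyl in place of 2-methoxyethyl gives a 6.3-fold higher number from compound 2 to compound 3 (0.80 log units; beyond the scatter), so phenyl has the highest number against both chains, and both steps lie beyond the scatter. No measured evidence accompanies these compounds that could account for this result.

The compounds shown leave open whether the aromatic ring itself or the removal of a flexible chain sets the higher number. Benzyl, cyclohexyl or a longer chain such as hexyl on that nitrogen would help to separate the two.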